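A few compounds are considered here, and "the series" means these few. Any claim that something is new, unique, unknown or untested is made for them only; others in the source may bear on it.

Of the compounds shown here, three that share a core have been read in an ADME assay on microsomes from liver (Mus musculus) for metabolic stability, read by LC-MS, using NADPH, tested at 4.6 uM; on this read-out higher numbers stand for a longer-lived compound and lower numbers for a shorter-lived compound. Compound 1 `CCOCCNC(=O)n1cc(-c2ccccc2)oc1=O` reports only a limit, < 0.0834 h. Compound 2 `CC(C)CNC(=O)n1cc(-c2ccccc2)oc1=O` gives 0.833 h. Here isopropyl stands in place of ethoxymethyl on a saturated chain carbon, and the step is an at least 9.9-fold higher number from compound 1 to compound 2 (0.99 log units; beyond the scatter). That step starts from the limit of < 0.0834 h in this assay, at which 1 of the 3 values shown sits. Compound 3 `COc1cccc(-c2cn(C(=O)NCCCCc3ccccc3)c(=O)o2)c1` gives 0.5 h, which lies within the usual scatter of the number for compound 2.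

Compound 4 `O=C(NCCCCc1ccccc1)n1cc(-c2ccccn2)oc1=O` differs from compound 3 in one place: pyridin-2-yl in place of 3-methoxyphenyl on an aromatic carbon. In short, pyridin-2-yl replaces 3-methoxyphenyl on an aromatic carbon. Among the compounds with values here, the only measured step, an at least 9.9-fold higher number from compound 1 to compound 2 (0.99 log units; beyond the scatter), lies on the chain and not at this aromatic carbon, so it gives no direct size for this change. No step beyond the scatter is therefore expected, with compound 3 at 0.5 h as the starting point. The estimated step is no change at the digits printed from compound 3 to compound 4 (within the scatter). For compound 4 the expected half-life is 0.5 h, with an estimated range of 0.15 h to 1.5 h.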

Compound 4, half-life: 0.167 h
Beside the measured number, compound 4's estimate is 3.0-fold (0.48 log units) above it, and the stated range covers the measured number.
By their numbers in this assay, from the lowest: compound 4; then compounds 3 and 2 (each within the scatter of the next). At a limit, below all of these: compound 1.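

The group on the aromatic carbon next to the ring oxygen matters for survival in this assay: pyridin-2-yl in place of 3-methoxyphenyl gives a 3.0-fold lower number from compound 3 to compound 4 (0.48 log units; beyond the scatter). Within the data shown here, the only earlier step lay on the chain, so this is the first measured sign that this end of the molecule also affects half-life. The swap replaces a carbon-only aromatic ring bearing a methoxy group with an aromatic ring holding one hetero atom, and nothing measured here explains the shorter half-life or separates those two differences.

Still open, going by these compounds, is how a pyridin-3-yl or pyridin-4-yl group would read at this same carbon, which would show whether the place of the ring nitrogen counts. Also open, on these data alone, is whether this swap would give a similar step on the side chain of compound 2.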